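The source may report more compounds than this note shows. Statements on the series, on what has been measured and on what is new or still open speak of the compounds shown alone.

Measured in a functional assay on HeLa cells (Homo sapiens) for antiproliferative activity, read by MTT assay, with a stated time of 3 days; a lower number here means a stronger inhibitor, a higher number a weaker inhibitor:
compound 1 `CCCCc1ccc(C#Cc2cn(C/C=C/CN3C(=O)c4ccccc4C3=O)c(=O)[nH]c2=O)cc1` gives 94000 nM.
compound 3 `O=C1c2ccccc2C(=O)N1C/C=C/Cn1cc(C#CCCc2ccccc2)c(=O)[nH]c1=O` gives 29000 nM.
compound 2 `O=C1c2ccccc2C(=O)N1C/C=C\Cn1cc(C#CCCc2ccccc2)c(=O)[nH]c1=O` gives > 100000 nM, which is a limit of the assay and not a number.

Compound 2 and compound 3 share every atom and bond; the difference between the two cores is the two compounds have the same atoms and bonds and differ only in configuration as drawn: 1 of 1 stereo elements differ; a double bond is drawn E in compound 3 and Z in compound 2. The step across it is an at least 3.4-fold lower number from compound 2 to compound 3 (0.53 log units; beyond the scatter). Its size is known only as a lower bound because the limit of > 100000 nM in this assay, at which 1 of the 3 values shown sits, holds for compound 2, and that it belongs to configuration alone follows from the fact that compounds 2 and 3 differ only in the configuration as drawn.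

The change of interest is 4-butylphenyl in place of phenethyl on a triple-bonded carbon, which made a 3.2-fold higher number from compound 3 to compound 1 (0.51 log units; beyond the scatter) in this assay. Compound 4 `CCCCc1ccc(C#Cc2cn(C/C=C\CN3C(=O)c4ccccc4C3=O)c(=O)[nH]c2=O)cc1` carries the same change made on compound 2: 4-butylphenyl in place of phenethyl on a triple-bonded carbon. The place is the same in both pairs, so this is the same change, not merely the same kind. The step is expected to be a step that the limit leaves unreadable from compound 2 to compound 4, resting on the measured 3.2-fold higher number from compound 3 to compound 1 (0.51 log units; beyond the scatter). Since compound 2 already sits at a limit, the expected outcome for compound 4 is a value of 300000 nM, between 100000 nM and 1000000 nM, and most likely a limit is again all that this assay will report.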

Compound 4, half-maximal inhibitory concentration: 85000 nM
Compound 4: middle estimate off by 3.5-fold (0.55 log units), on the high side, outside the stated range (below it).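

In this assay, 4-butylphenyl in place of phenethyl on a triple-bonded carbon did not behave alike on the two cores: the same change on two cores in this assay, a 3.2-fold higher number (0.51 log units; beyond the scatter) from compound 3 to compound 1 and an at least 1.1-fold lower number (0.07 log units; that floor lies within the scatter) from compound 2 to compound 4, at least 3.8-fold (0.58 log units) apart, beyond the scatter of two such steps

The step on the Z-drawn core, an at least 1.1-fold lower number from compound 2 to compound 4 (0.07 log units; that floor lies within the scatter), is only a floor, so its true size and direction are not shown, and two pairs give no rule for other cores; configuration gave an at least 3.4-fold lower number from compound 2 to compound 3 (0.53 log units; beyond the scatter) with phenethyl but a 1.1-fold lower number from compound 1 to compound 4 (0.04 log units; within the scatter) with 4-butylphenyl: the fact that compounds 1 and 4 differ only in the configuration as drawn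

Compound 2 stands at > 100000 nM, a limit of the assay and not a number: the limit of > 100000 nM in this assay, at which 1 of the 4 values shown sits.

Still open, on these data alone, is whether the configuration step seen with phenethyl returns with other groups on the triple-bonded carbon, such as a chain longer than butyl, an amine or a carboxylic acid. Also open, as far as these compounds go, is whether any such group brings the E and Z compounds apart again in this assay, or moves either one clear of the values seen here.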